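Nitro for hydrogen on two cores: antiproliferative notes

The source may report more compounds than this note shows. Statements on the series, on what has been measured and on what is new or still open speak of the compounds shown alone.

Compound 2 `CCOc1ccc2nc(Cl)c(/C=N/NC(=O)c3cc4ccccc4oc3=O)cc2c1` and compound 1 `CCOc1ccc2nc(Cl)c(/C=N/NC(=O)c3cc4cc([N+](=O)[O-])ccc4oc3=O)cc2c1` share one core; compound 3 `Cc1noc(NS(=O)(=O)c2ccc(NC(=O)c3cc4ccccc4oc3=O)cc2)c1C` and compound 4 `Cc1noc(NS(=O)(=O)c2ccc(NC(=O)c3cc4cc([N+](=O)[O-])ccc4oc3=O)cc2)c1C` share another. The difference between the two cores is not broken down here. In a functional assay on CCRF-CEM cells (Homo sapiens) for antiproliferative activity, read by fluorescence and resazurin assay, with a stated time of 48 h (a higher number here means a weaker inhibitor, a lower number a stronger inhibitor), compound 2 gives 6320 nM. Compound 1 gives 15700 nM. The change between them is nitro in place of hydrogen on an aromatic carbon. Compound 3 gives 26600 nM; against compound 1 this lies within the scatter, against compound 2 beyond it. Compound 4 has not yet been measured. From compound 3 to compound 4 the change is nitro in place of hydrogen on an aromatic carbon, the same change as from compound 2 to compound 1, at a place described in the same words but on a different core. Among the measured compounds shown here, the step from compound 3 to compound 4 is expected to be a 2.3-fold higher number from compound 3 to compound 4 (0.35 log units; beyond the scatter), because the single earlier instance of this change gave a 2.5-fold higher number from compound 2 to compound 1 (0.40 log units; beyond the scatter), and only one such pair is available, so the range is kept wide. Compound 4 is therefore estimated at 60000 nM, with the expected range running from 25000 nM to 150000 nM.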

Compound 4, half-maximal inhibitory concentration: 14300 nM
Beside the measured number, compound 4's estimate is 4.2-fold (0.62 log units) above it, outside the stated range (below it).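

In this assay, nitro in place of hydrogen on an aromatic carbon gives a 1.9-fold lower number from compound 3 to compound 4 (0.27 log units; within the scatter), so this pair stays within the scatter, whereas the same change on the core of compound 2 gave a step beyond it. Among the compounds shown here, the change therefore does not carry over between these two cores as a fixed increment, and the two steps differ by more than repeated measurement would explain: the same change on two cores in this assay, a 2.5-fold higher number (0.40 log units; beyond the scatter) from compound 2 to compound 1 and a 1.9-fold lower number (0.27 log units; within the scatter) from compound 3 to compound 4, 4.6-fold (0.66 log units) apart, beyond the scatter of two such steps This does not show why the cores part ways, which portion of each core is responsible, or that the nitro group is without consequence on the core of compound 3, and each core supplies only a single pair.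

Open, going by these compounds, is whether an amine or a methoxy group on the same aromatic carbon would split between the two cores as nitro does. Also open, on these data alone, is whether the divergence between the cores would persist in any other cell line or read-out.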